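This account rests on a few compounds, and the source may have more. Where it says the series, first, only, none or still open, it means among the compounds named here.

In a toxicity assay on THP-1 cells (Homo sapiens) for inhibition (a higher number here means that more compound is tolerated, a lower number that less compound is tolerated), compound 1 (`COc1ccc(-c2cnc(NC(=O)c3ccc(F)cc3)n2-c2ccccc2)cc1`) gives 8800 nM. Compound 2 (`COc1ccc(-c2cnc(NC(=O)c3ccc(F)cc3)n2C2CCCC2)cc1`) gives > 100000 nM, which is a limit of the assay and not a number, so it stands at the limit of > 100000 nM in this assay, at which 1 of the 2 values shown sits. For the measured compounds named here, the one measured step, an at least 11-fold higher number from compound 1 to compound 2 (1.05 log units; beyond the scatter), was large and exchanged phenyl for cyclopentyl on the same aromatic nitrogen. Compound 3 (`COc1ccc(-c2cnc(NC(=O)c3ccc(F)cc3)n2C(C)C)cc1`) carries isopropyl in place of cyclopentyl on that nitrogen (isopropyl in place of cyclopentyl on an aromatic nitrogen). Neither group is aromatic, whereas the large step from compound 1 to compound 2 an at least 11-fold higher number from compound 1 to compound 2 (1.05 log units; beyond the scatter) removed the phenyl, so only a small change is expected here, if any, towards a lower number in this assay. The expected change is an at least 1.2-fold lower number from compound 2 to compound 3 (0.09 log units; that floor lies within the scatter). For compound 3 the estimated value is 80000 nM, with an expected range from 25000 nM to 100000 nM.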

Compound 3, half-maximal cytotoxic concentration: > 50000 nM
Compound 3: no number, only a limit (the forecaster's own chance of this, stated with the estimate: 55%); the middle value is on the limit's open side.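

Compound 3 also ends in a limit of the assay and not a number: the limit of > 50000 nM in this assay, at which 1 of the 3 values shown sits. Isopropyl, which has no ring, gives an at least 5.6-fold higher number from compound 1 to compound 3 (0.75 log units; beyond the scatter), so a ring of carbon on this aromatic nitrogen is not needed for the number in this assay to stand clear of that of compound 1. As far as these compounds go, the step between cyclopentyl and isopropyl cannot be read, as compound 2 and compound 3 both carry limits, and so the order of these two compounds stays unknown.

The compounds shown leave open where the true values of compound 2 and compound 3 lie. They also leave open whether a benzyl group or a longer chain ending in an amine on this nitrogen would keep the number clear of that of compound 1.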